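This account rests on a few compounds, and the source may have more. Where it says the series, first, only, none or still open, it means among the compounds named here.

Measured in a functional assay on KB cells (Homo sapiens) for inhibition, read by sulforhodamine B assay, with a stated time of 72 h; on this read-out lower numbers stand for stronger inhibition of growth and higher numbers for weaker inhibition of growth:
- Compound 1 `CN1CCN(C(=O)/C=C/c2ccncc2-c2ccc3ccccc3c2)CC1` gives > 10000 nM, which is a limit.
- Compound 2 `CCOC(=O)/C=C/c1ccncc1-c1ccc2[nH]ccc2c1` gives > 10000 nM, which is a limit.
- Compound 3 `CCOC(=O)/C=C/c1ccncc1-c1ccc2cc[nH]c2c1` gives 7860 nM.

Compound 1 has no exact number and stands at the limit of > 10000 nM in this assay, at which 2 of the 3 values shown sit. Compound 4 `COC1CN(C(=O)/C=C/c2ccncc2-c2ccc3ccccc3c2)C1` differs from it in one place, with 3-methoxyazetidin-1-yl in place of 4-methylpiperazin-1-yl on a carbonyl carbon. Within the data shown here, no measured pair tests this change, so the expectation rests on the limit of compound 1 and the weak growth inhibition seen across the set. The estimated step is a step that the limit leaves unreadable from compound 1 to compound 4, and no change beyond the usual scatter is expected in this assay. For compound 4 the expected value is 12000 nM, with an estimated range from 6000 nM to 25000 nM.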

Compound 4, concentration for 50% growth inhibition: > 10000 nM
Compound 4 was reported as a limit; the forecaster's own chance of this, stated with the estimate: 70%; the middle value does not contradict the limit.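

Compound 1 and compound 4 are both reported only as limits, so no step between them can be read: the limit of > 10000 nM in this assay, at which 3 of the 4 values shown sit.

On these data alone, whether 3-methoxyazetidin-1-yl in place of 4-methylpiperazin-1-yl changes growth inhibition at all remains open.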